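Dimethylamino for methoxy on the shared core of compound 1

The compounds below may be only part of what the source reports. "The series", "measured", "known", "first", "only" and "open" are said of these compounds alone.

Compound 1 `COc1ccc(C2CC(c3ccccc3)=NN2C2=NC(=O)/C(=C3\C(=O)Nc4ccccc43)S2)cc1` gives 3350 nM in a functional assay on cells (Cancer cell lines, Homo sapiens) for cytotoxicity, read by sulforhodamine B assay, with a stated time of 48 h (a higher number here means a weaker inhibitor of growth, a lower number a stronger inhibitor of growth), the highest of the three numbers here; compound 3 `COc1ccc(C2CC(c3ccc4ccccc4c3)=NN2C2=NC(=O)/C(=C3\C(=O)Nc4ccccc43)S2)cc1` at 2470 nM sits within the scatter of it, compound 2 `COc1ccc(C2CC(c3ccccc3)=NN2C2=NC(=O)/C(=C3\C(=O)Nc4ccc(Br)cc43)S2)cc1` at 660 nM beyond it. Compound 4 `CN(C)c1ccc(C2CC(c3ccccc3)=NN2C2=NC(=O)/C(=C3\C(=O)Nc4ccccc43)S2)cc1` differs from compound 1 by dimethylamino in place of methoxy on an aromatic carbon. Neither measured step touches this position: a 5.1-fold lower number from compound 1 to compound 2 (0.71 log units; beyond the scatter) and a 1.4-fold lower number from compound 1 to compound 3 (0.13 log units; within the scatter) change other parts of the core. A change at the methoxy position is therefore uncharted, and no direction can be read from the series; the expectation is a step of about a 1.3-fold lower number from compound 1 to compound 4 (0.13 log units; within the scatter), most likely within the scatter. Compound 4 is thus estimated at 2500 nM, with a range of 800 nM to 8000 nM.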

Compound 4, concentration for total growth inhibition: 34000 nM
Estimate against measurement, compound 4: 14-fold (1.13 log units) below; measured number outside the range, above it.
By their numbers in this assay, from the lowest: compound 2; then compounds 3 and 1 (each within the scatter of the next); then compound 4.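

In this assay, the change from 4-methoxyphenyl to 4-(dimethylamino)phenyl gives a 10-fold higher number from compound 1 to compound 4 (1.01 log units; beyond the scatter). For the compounds shown here, this position is therefore not neutral: it carries the only step beyond the scatter toward a higher number, whereas the steps at the other two places run toward lower numbers. Nothing shown accounts for this loss. On these data alone, whether hydroxy, ethoxy or chloro at this place would hold, lower or raise the number of compound 1 remains open. Also open, as far as these compounds go, is whether bromo on the shared core would still lower the number with dimethylamino present.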